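Bis-aziridinyl quinones: chain variation at the ring carbon

The source may report more compounds than this note shows. Statements on the series, on what has been measured and on what is new or still open speak of the compounds shown alone.

Measured compounds in a functional assay on L1210 cells (Mus musculus), with a stated time of 1 days; a lower number here means a less potent compound, a higher number a more potent compound, by a factor of ten per unit of this negative logarithm:
- compound 1, `CC1=C(N2CC2)C(=O)C(CC(C)OC(N)=O)=C(N2CC2)C1=O`: 5.18
- compound 2, `CC1=C(N2CC2)C(=O)C(Cc2ccccc2)=C(N2CC2)C1=O`: 4.26
- compound 3, `COCCC1=C(N2CC2)C(=O)C(C)=C(N2CC2)C1=O`: 5.12

Compound 3 stands second highest of the three numbers. Its nearest neighbour is compound 1, whose value in this assay is within the scatter of that of compound 3, so no order between them can be claimed. Its furthest neighbour is compound 2, and the step of a number 0.86 log units higher from compound 2 to compound 3 (beyond the scatter) is beyond the scatter.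

Compound 4, `CC1=C(N2CC2)C(=O)C(C(C)COC(N)=O)=C(N2CC2)C1=O`, has not yet been measured. The change from compound 3 is a group of 7 heavy atoms (4 carbon, 1 nitrogen, 2 oxygen; no ring) in place of a group of 4 heavy atoms (3 carbon, 1 oxygen; no ring), on a double-bonded ring carbon.

The step that bears on this is a number 0.06 log units lower from compound 1 to compound 3 (within the scatter), which is within the scatter: exchanging a chain carrying a carbamate for a methoxyethyl chain left the number essentially unchanged. Compound 4 reintroduces a chain of the same kind as in compound 1, differing only in where the methyl sits along it. A step of no more than the scatter is therefore expected, and the value of compound 4 is estimated near that of compound 1.

Compound 4 is expected to give 5.15, within 4.7 to 5.6, which means an expected step of a number 0.03 log units higher from compound 3 to compound 4 (within the scatter).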

Compound 4, logarithm of the reciprocal of the active concentration, log(1/C): 5.31
Beside the measured number, compound 4's estimate is 0.16 log units below it, and the stated range covers the measured number.
By their numbers in this assay, from the lowest: compound 2; then compounds 3, 1 and 4 (each within the scatter of the next).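

In this assay, relocating the methyl along the carbamate chain gives a number 0.13 log units higher from compound 1 to compound 4 (within the scatter), and exchanging the 2-methoxyethyl chain for this carbamate chain, which adds a hydrogen-bond donor, gives a number 0.19 log units higher from compound 3 to compound 4 (within the scatter), so neither change separates the compounds at this position. The chain with the six-membered aromatic ring stands apart from the new chain, with a number 1.05 log units higher from compound 2 to compound 4 (beyond the scatter), and among the four compounds only compound 2 lies beyond the scatter of the others. No measurement available here explains the steps at this position.

On these data alone, whether this level holds with an amine or a carboxylic acid at the chain end, or with a longer chain, remains open. A cyclohexylmethyl group would test whether the low value of compound 2 depends on the aromatic ring itself.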